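The source may hold more compounds than are shown below. What is called first, only, known or untested is meant among the compounds shown, and "the series" means these compounds.

Three compounds have so far been measured in a functional assay on A549 cells (Homo sapiens) for cytotoxicity, read by MTT assay, with a stated time of 72 h; on this read-out lower numbers stand for stronger inhibition and higher numbers for weaker inhibition:

Compound 1, `O=C(Nc1ccc(Oc2ccnc3[nH]ccc23)c(F)c1)c1nn(-c2ccc(Br)cc2F)ccc1=O`, gives 55700 nM.
Compound 2, `O=C(Nc1ccc(Oc2ccnc3[nH]ccc23)c(F)c1)c1nn(-c2ccc(Cl)c(F)c2)ccc1=O`, gives 10300 nM.
Compound 3, `Cn1ccc2c(Oc3ccc(NC(=O)c4nn(-c5ccc(Br)cc5F)ccc4=O)cc3)ccnc21`, gives 35700 nM.

Compound 1 and compound 2 share one core and differ only in the group on the aromatic nitrogen: 4-chloro-3-fluorophenyl in place of 4-bromo-2-fluorophenyl on an aromatic nitrogen. That single change produced a 5.4-fold lower number from compound 1 to compound 2 (0.73 log units; beyond the scatter). Compound 3 is built on a different core; how its core differs from that of compound 1 is not broken down here. The numbers of compound 3 and compound 1 lie within the scatter of each other, whereas compound 2 stands beyond the scatter lower than either.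

Compound 4, `Cn1ccc2c(Oc3ccc(NC(=O)c4nn(-c5ccc(Cl)c(F)c5)ccc4=O)cc3)ccnc21`, has not yet been measured in this assay. It relates to compound 3 as compound 2 relates to compound 1: 4-chloro-3-fluorophenyl in place of 4-bromo-2-fluorophenyl on an aromatic nitrogen. The surroundings of the place are described in identical words for both pairs, so this is the same change. If the earlier step carries over, the expected step is a 4.5-fold lower number from compound 3 to compound 4 (0.65 log units; beyond the scatter), which rests on a 5.4-fold lower number from compound 1 to compound 2 (0.73 log units; beyond the scatter) and on the starting point of compound 3 at 35700 nM. Going by the values given here, only one earlier example of the change exists. The expected step is therefore taken somewhat smaller than the earlier one. Compound 4 is estimated at 8000 nM, with a likely range from 3000 nM to 25000 nM.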

Compound 4, half-maximal inhibitory concentration: > 60000 nM
Compound 4 ended at the assay's limit; the forecaster's own chance of this, stated with the estimate: 5%; middle value at least 7.5-fold (0.87 log units) from the limit.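

In this assay compound 4 gives > 60000 nM, which is a limit of the assay and not a number: the limit of > 60000 nM in this assay, at which 1 of the 4 values shown sits. On the core of compound 3, 4-chloro-3-fluorophenyl in place of 4-bromo-2-fluorophenyl gave an at least 1.6-fold higher number from compound 3 to compound 4 (0.22 log units; that floor lies within the scatter), so the lower number seen on the core of compound 1 did not recur and the step cannot be carried from one core to the other in this series: the same change on two cores in this assay, a 5.4-fold lower number (0.73 log units; beyond the scatter) from compound 1 to compound 2 and an at least 1.6-fold higher number (0.22 log units; that floor lies within the scatter) from compound 3 to compound 4, at least 9.0-fold (0.95 log units) apart, beyond the scatter of two such steps. This shows only that the outcome of the change depends on the core in these two pairs; it rests on one pair per core, gives no true size for the second step, and does not show which difference between the cores is responsible.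

The compounds shown leave open how the same change would behave on any further core, and whether exchanging bromine for chlorine alone would give the same split. They also leave open whether an amine or a carboxylic acid on the group at the aromatic nitrogen would follow the same course on both cores.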